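Changing the Benzyl Ether on a Shared Core

The source may hold more compounds than are shown below. What is called first, only, known or untested is meant among the compounds shown, and "the series" means these compounds.

Compound 1 `O=C(O)c1nn(Cc2cc(Br)ccc2OCc2ccccc2)cc1Cl` carries the same core as the others, and in a functional assay on CHO-K1 cells for antagonist activity at prostaglandin E2 receptor EP1 subtype (Homo sapiens), read by FLIPR (on this read-out higher numbers stand for weaker inhibition and lower numbers for stronger inhibition), compound 1 gives < 2000 nM, which is a limit of the assay rather than a number (the limit of < 2000 nM in this assay, at which 1 of the 3 values shown sits). Compound 2 `Cc1cc(C(=O)O)nn1Cc1cc(Br)ccc1OCc1ccc(Cl)cc1` gives 8.71 nM in this assay. Compound 3 `Cc1cc(C(=O)O)nn1Cc1cc(Br)ccc1OCc1ccc(C(F)(F)F)cc1` gives 97.7 nM in this assay. Among the two numbers shown, compound 2 stands lowest; the one step to it, an 11-fold higher number from compound 2 to compound 3 (1.05 log units; beyond the scatter), is a large change and lies beyond the scatter.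

Compound 4 `Cc1cc(C(=O)O)nn1Cc1cc(Br)ccc1OCc1c(F)cccc1F` is not yet measured. It differs from compound 2 by 2,6-difluorophenyl in place of 4-chlorophenyl on a saturated chain carbon bound to an oxygen on an aromatic ring. For the measured compounds named here, the only measured step on this benzyl ether is the one from compound 2 to compound 3, where trifluoromethyl in place of chloro raised the number by an 11-fold higher number from compound 2 to compound 3 (1.05 log units; beyond the scatter). The change to compound 4 touches the same benzyl ether but replaces the ring pattern rather than swapping one substituent for another, so that step is only a partial guide. He therefore expects a modest rise in this assay, smaller than the measured step, rather than none at all. His estimate for compound 4 is 30 nM, between 6 nM and 200 nM, which means an expected step of a 3.4-fold higher number from compound 2 to compound 4 (0.54 log units; beyond the scatter).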

Compound 4, inhibition constant: 105 nM
Estimate against measurement, compound 4: 3.5-fold (0.54 log units) below; the range from low to high includes it.
By their numbers in this assay, from the lowest: compound 2; then compounds 3 and 4 (each within the scatter of the next).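

In this assay, the second change at this position also gives a large step: a 12-fold higher number from compound 2 to compound 4 (1.08 log units; beyond the scatter). The loss therefore does not belong to the trifluoromethyl swap alone, since 2,6-difluorophenyl in place of 4-chlorophenyl, on the same saturated chain carbon bound to an oxygen on an aromatic ring, also leaves the number well clear of compound 2, and compound 3 and compound 4 now sit within the scatter of each other, so that on these few compounds compound 2 stands alone as the lowest number with both of its steps beyond the scatter. Nothing shown here accounts for either rise, as the only supporting information concerns an assay limit and says nothing about this change.

The change to compound 4 removes the chloro and brings in the two fluorines in one move, so the compounds shown do not separate the loss of chloro from the arrival of the 2,6-difluoro pattern. As far as these compounds go, it also stays open whether a bromo or a methoxy group in place of the chloro of compound 2, or a longer chain carrying the 4-chlorophenyl, would hold the number of compound 2.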